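This account rests on a few compounds, and the source may have more. Where it says the series, first, only, none or still open, it means among the compounds named here.

Compound 3 `C=CC1=C(C(=O)Nc2ccccc2)C(c2ccc(F)cc2)OC1` sits at the low end of three numbers in a functional assay on QGY7701 cells (Homo sapiens) for cytotoxicity, read by MTT assay, with a stated time of 24 h (on this read-out higher numbers stand for weaker inhibition and lower numbers for stronger inhibition), giving 46700 nM, while compound 1 `C=CC1=C(C(=O)Nc2ccc(C)cc2)C(c2ccc(F)cc2)OC1` gives 59200 nM and compound 2 `C=CC1=C(C(=O)NCc2ccc(C)cc2)C(c2ccc(F)cc2)OC1` gives 62100 nM; the steps of a 1.3-fold lower number from compound 1 to compound 3 (0.10 log units; within the scatter) and a 1.3-fold lower number from compound 2 to compound 3 (0.12 log units; within the scatter) are both within the scatter, so the three stand together. Compound 4 `C=CC1=C(C(=O)NCCCCC)C(c2ccc(F)cc2)OC1` carries one change on compound 3: pentyl in place of phenyl on an amide-type nitrogen. Among the measured compounds shown here, no measured step trades an aromatic group for a chain on that nitrogen; the nearest comparison is a 1.0-fold higher number from compound 1 to compound 2 (0.02 log units; within the scatter), where the amide substituent changed by one unit and the number barely moved. On this evidence compound 4 is expected to show a 1.1-fold higher number from compound 3 to compound 4 (0.03 log units; within the scatter), nothing beyond the scatter, and its estimated value is 50000 nM with a range from 25000 nM to 100000 nM.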

Compound 4, half-maximal inhibitory concentration: > 100000 nM
Compound 4: no number, only a limit; the forecaster's own chance of this, stated with the estimate: 15%; middle value at least 2.0-fold (0.30 log units) away from the limit.
By their numbers in this assay, from the lowest: compounds 3, 1 and 2 (each within the scatter of the next). At a limit, above all of these: compound 4.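

Compound 4 gives no number in this assay, only a limit: (the limit of > 100000 nM in this assay, at which 1 of the 4 values shown sits). Among the compounds shown here, at the amide-type nitrogen, pentyl in place of phenyl gives an at least 2.1-fold higher number from compound 3 to compound 4 (0.33 log units; beyond the scatter), the only step so far to pass the scatter, whereas the aromatic substituents of compound 1, compound 2 and compound 3 stood together. The other two comparisons are looser, with an at least 1.6-fold higher number from compound 2 to compound 4 (0.20 log units; that floor lies within the scatter) and an at least 1.6-fold higher number from compound 1 to compound 4 (0.22 log units; that floor lies within the scatter), so they separate nothing. The compounds shown leave open whether a shorter chain such as propyl, or a cyclohexyl ring, on that nitrogen would stay with compound 3 or with compound 4.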